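A few compounds are considered here, and "the series" means these few. Any claim that something is new, unique, unknown or untested is made for them only; others in the source may bear on it.

In a physicochemical assay for lipophilicity (a higher number here means a more lipophilic compound, a lower number a more polar compound), compound 2 (`C[C@H]1CC[C@@H]2[C@@H](OC(=O)[C@]23CC(c2ccc(F)cc2)N(c2ccccc2)O3)[C@]2(C)C(=O)C=C[C@@]12O`) gives 3.35 and stands lowest of the two measured compounds, under compound 1 (`C[C@H]1CC[C@@H]2[C@@H](OC(=O)[C@]23CC(c2ccc(Br)cc2)N(c2ccccc2)O3)[C@]2(C)C(=O)C=C[C@@]12O`) with 4 as its number. Compound 3 (`C[C@H]1CC[C@@H]2[C@@H](OC(=O)[C@]23CC(c2ccc(C#N)cc2)N(c2ccccc2)O3)[C@]2(C)C(=O)C=C[C@@]12O`) differs from compound 2 by cyano in place of fluoro on an aromatic carbon in one place, with cyano in place of fluoro on an aromatic carbon. For the measured compounds named here, one measured step bears on this, the modest a number 0.65 log units lower from compound 1 to compound 2 (beyond the scatter) at that same aromatic carbon. A step of similar size towards a lower number is therefore expected in this assay and is estimated as a number 0.50 log units lower from compound 2 to compound 3 (beyond the scatter) here. Compound 3 is expected at 2.85 within an estimated range of 2.5 to 3.25 in all.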

Compound 3, partition coefficient: 2.94
Estimate against measurement, compound 3: 0.09 log units below; the measured number falls inside the stated range.
By their numbers in this assay, from the lowest: compound 3; then compound 2; then compound 1.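

Replacing fluoro with cyano gives a number 0.41 log units lower from compound 2 to compound 3 (beyond the scatter) in this assay, and replacing bromo with cyano gives a number 1.06 log units lower from compound 1 to compound 3 (beyond the scatter), the largest step seen at this position. The three groups at this carbon are therefore separated beyond the scatter, with cyano lowest, fluoro in the middle and bromo highest. No evidence is at hand that explains this order. Where an amine or a carboxylic acid at this carbon would fall remains open. So does whether these steps would hold with a different group on the nitrogen of the shared core.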